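This account rests on a few compounds, and the source may have more. Where it says the series, first, only, none or still open, it means among the compounds named here.

In a functional assay on NCI-H23 cells (Homo sapiens) for cytotoxicity, read by sulforhodamine B assay, with a stated time of 48 h, tested at 0.1 uM (on this read-out lower numbers stand for a stronger effect and higher numbers for a weaker effect at the one concentration tested), compound 1 `COc1ccc(C(=O)/C=C/c2cc(-c3cc(OC)c(OC)c(OC)c3)n[nH]2)cc1OC` gives 94%, the highest of the three numbers shown but within the scatter of both others; compound 2 `COc1ccc(C(=O)/C=C/c2cc(-c3cc(OC)c(OC)c(OC)c3)n[nH]2)cc1` gives 92% and compound 3 `COc1cc(-c2cc(/C=C/C(=O)c3ccc(F)c(F)c3)[nH]n2)cc(OC)c1OC` gives 92%. The steps of a number 2 percentage points lower from compound 1 to compound 2 (within the scatter) and a number 2 percentage points lower from compound 1 to compound 3 (within the scatter) stay within the scatter, as does no change at the digits printed from compound 2 to compound 3 (within the scatter). Compound 4 `COc1cc(C(=O)/C=C/c2cc(-c3cc(OC)c(OC)c(OC)c3)n[nH]2)cc(OC)c1OC` differs from compound 1 in one place: methoxy in place of hydrogen on an aromatic carbon. For the measured compounds named here, the only measured step that bears on this change runs in the opposite sense, a number 2 percentage points lower from compound 1 to compound 2 (within the scatter), and is within the scatter. Adding a methoxy is therefore expected to leave the read-out essentially where it is. For compound 4 the expected step is a number 1 percentage points lower from compound 1 to compound 4 (within the scatter). Compound 4 is estimated at 93%, with a range from 84% to 100%.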

Compound 4, a percentage reported as activity, at one concentration (the size of the read-out at that concentration, not a potency): 101%
Beside the measured number, compound 4's estimate is 8 percentage points below it; the whole stated range lies below it.
By their numbers in this assay, from the lowest: compounds 2, 3, 1 and 4 (each within the scatter of the next).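

In this assay, for the compounds shown here, a number 7 percentage points higher from compound 1 to compound 4 (within the scatter) is the only direct reading of a methoxy entering this ring carbon, ortho to a methoxy group and meta to a large group, and it stays within the scatter. Read with a number 2 percentage points lower from compound 1 to compound 2 (within the scatter), neither gaining nor losing a methoxy on this ring moves the read-out beyond the scatter. No measured evidence accounts for this result.

As far as these compounds go, whether an amine, a carboxylic acid or a longer alkoxy chain at this ring carbon would move the read-out beyond the scatter remains open. The behaviour of these compounds at other concentrations also remains open.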